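The compounds below may be only part of what the source reports. "The series", "measured", "known", "first", "only" and "open" are said of these compounds alone.

Measured so far:
compound 1 `C=CCn1c(SCC(=O)Nc2ccc(C(C)=O)cc2)nnc1-c1ccccc1` – 63%
compound 2 `C=CCn1c(SCC(=O)Nc2ccc(/C(C)=N/O)cc2)nnc1-c1ccccc1` – 71%
compound 3 `C=CCn1c(SCC(=O)Nc2ccc(C(C)=O)cc2)nnc1-c1ccc(OC)cc1` – 66%

In a functional assay on the whole organism (strain albino) for inhibition, with Rattus norvegicus as the target, read by paw edema, with stated times of 30 min and 5 h, at a dose of 0.28 mmol/kg by the oral route (a higher number here means more inhibition at the dose given (going by the name of the read-out), a lower number less inhibition), compound 1 gives 63%, the lowest of the three numbers, though neither of the other two compounds lies beyond the scatter from it. Compound 4 is `CC(=O)c1ccc(NC(=O)CSc2nnc(-c3ccccc3)n2-c2ccccc2)cc1`; it differs from compound 1 by phenyl in place of allyl on an aromatic nitrogen. Within the data shown here, no measured step touches this position: the two known steps, a number 8 percentage points higher from compound 1 to compound 2 (within the scatter) and a number 3 percentage points higher from compound 1 to compound 3 (within the scatter), concern other parts of the molecule and are both within the scatter. Nothing in the series therefore points to a change beyond the scatter for compound 4, and the step from compound 1 is expected as a number 1 percentage points lower from compound 1 to compound 4 (within the scatter). For compound 4 in this assay the estimate is 62%, with a range from 47% to 77%.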

Compound 4, a percentage reported as inhibition, in the whole organism at one dose (the size of the read-out at that dose, not a potency): 63%
For compound 4 the middle estimate is 1 percentage points below the measured one; low and high end bracket the measured number.
By their numbers in this assay, from the lowest: compounds 1, 4, 3 and 2 (each within the scatter of the next).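

Phenyl in place of allyl on the aromatic nitrogen reads in this assay as no change at the digits printed from compound 1 to compound 4 (within the scatter) and so gives the first measured step at this position. The position therefore takes a six-membered aromatic ring of carbon only in place of the allyl chain, with no shift beyond the scatter at this single dose. Nothing measured bears on why the two groups read alike.

Open, as far as these compounds go, is how a methyl group, a longer alkyl chain or a benzyl group on this nitrogen would read. Also open, from the compounds shown here alone, is whether the two groups would still read alike at other doses.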